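Changing the Ring Group on an Aromatic Nitrogen

The compounds below may be only part of what the source reports. "The series", "measured", "known", "first", "only" and "open" are said of these compounds alone.

Measured so far in a functional assay on MDA-MB-468 cells (Homo sapiens) for cytotoxicity; a higher number here means a weaker inhibitor, a lower number a stronger inhibitor:
- compound 1 `C[C@@H]1O[C@@H](n2c3ccccc3c3c4c(c5c6ccccc6ccc5c32)C(=O)NC4=O)[C@H](O)[C@H](O)[C@H]1O` gives 5000 nM
- compound 2 `O=C1NC(=O)c2c1c1c3ccccc3ccc1c1c2c2ccccc2n1[C@H]1OC[C@@H](O)[C@@H](O)[C@H]1O` gives 3400 nM

On these numbers, compound 2 gives 3400 nM and sits within the usual scatter of compound 1, so the two cannot be told apart. The next compound, compound 3 `O=C1NC(=O)c2c1c1c3ccccc3ccc1c1c2c2ccccc2n1[C@@H]1O[C@H](CO)[C@@H](O)[C@H](O)[C@H]1O`, keeps the shared core and changes only the group on an aromatic nitrogen of a five-membered aromatic ring with 1 nitrogen: a group of 11 heavy atoms (6 carbon, 5 oxygen; one six-membered non-aromatic ring with 1 hetero atom) in place of a group of 9 heavy atoms (5 carbon, 4 oxygen; one six-membered non-aromatic ring with 1 hetero atom), on an aromatic nitrogen. The entering group is 3,4,5-trihydroxy-6-(hydroxymethyl)oxan-2-yl. Going by the values given here, only one measured step bears on this change, since it also swaps one such ring group for another on an aromatic nitrogen: a 1.5-fold lower number from compound 1 to compound 2 (0.17 log units; within the scatter). That is a single example, and it does not cover this new group. No step beyond the scatter is therefore expected in this assay, and neither direction can be favoured. The expected change is a 1.1-fold higher number from compound 2 to compound 3 (0.05 log units; within the scatter), which is a best guess and not a trend. Compound 3 is estimated at 3800 nM, and its value is expected to fall between 1500 nM and 10000 nM once measured.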

Compound 3, half-maximal inhibitory concentration: 6100 nM
For compound 3 the middle estimate is 1.6-fold (0.21 log units) below the measured one; measured number inside the range.
By their numbers in this assay, from the lowest: compounds 2, 1 and 3 (each within the scatter of the next).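

Setting 3,4,5-trihydroxy-6-(hydroxymethyl)oxan-2-yl on the aromatic nitrogen in place of 3,4,5-trihydroxy-6-methyloxan-2-yl gives a 1.2-fold higher number from compound 1 to compound 3 (0.09 log units; within the scatter) in this assay, and setting it in place of the group of 9 heavy atoms gives a 1.8-fold higher number from compound 2 to compound 3 (0.25 log units; within the scatter). Both steps lie within the scatter, so three different ring groups, spanning 9 to 11 heavy atoms and 3 to 4 hydrogen-bond donors, now cannot be told apart at this position, a statement that holds only for these three compounds. No accompanying measurement offers an explanation of how these results arise.

Going by these compounds, all three compounds carry a six-membered non-aromatic ring with 1 hetero atom on this nitrogen, so it remains open whether a plain ethyl chain there, or an amine or a carboxylic acid in place of the hydroxymethyl, would give a step beyond the scatter. Also open, on these data alone, is whether the same ring group with its stereocentres inverted would give a different number in this assay.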